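The source may report more compounds than this note shows. Statements on the series, on what has been measured and on what is new or still open speak of the compounds shown alone.

In a functional assay on RT-112 cells (Homo sapiens) for antiproliferative activity, read by MTT assay, with a stated time of 72 h; on this read-out higher numbers stand for weaker inhibition of growth and lower numbers for stronger inhibition of growth:
- compound 1 `COc1cc(NC(=O)Nc2cccc3c(Nc4cc(OC)cc(OC)c4)ncnc23)cc(OC)c1`: 366 nM
- compound 2 `COc1cc(Nc2ncnc3c(NC(=O)Nc4ccc(Cl)cc4)cccc23)cc(OC)c1`: 2490 nM

Compound 2 has the higher number of the two, so it inhibits growth less strongly. Compound 3 `CCOC(=O)c1ccc(NC(=O)Nc2cccc3c(Nc4cc(OC)cc(OC)c4)ncnc23)cc1` has ethoxycarbonyl in place of chloro on an aromatic carbon. Among the compounds with values here, one measured step bears on this, a 6.8-fold higher number from compound 1 to compound 2 (0.83 log units; beyond the scatter), which replaced the same 4-chlorophenyl group from the other direction. Within the data shown here, no measured compound carries the ester, so only a modest move towards a lower number in this assay is expected, with the direction uncertain. The expected change is a 2.1-fold lower number from compound 2 to compound 3 (0.32 log units; beyond the scatter). Estimated for compound 3 is 1200 nM, with a range from 350 nM to 4000 nM.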

Compound 3, concentration for 50% growth inhibition: 317 nM
Beside the measured number, compound 3's estimate is 3.8-fold (0.58 log units) above it; the measured number lies below the stated range.
By their numbers in this assay, from the lowest: compounds 3 and 1 (each within the scatter of the next); then compound 2.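

In this assay, the group on this ring clearly matters: ethoxycarbonyl in place of chloro gives a 7.9-fold lower number from compound 2 to compound 3 (0.90 log units; beyond the scatter), so the loss seen with compound 2 does not extend to every replacement of 3,5-dimethoxyphenyl. The step of a 1.2-fold lower number from compound 1 to compound 3 (0.06 log units; within the scatter) lies within the scatter, so 4-(ethoxycarbonyl)phenyl and 3,5-dimethoxyphenyl cannot be told apart here. No measurement given here explains the difference between ethoxycarbonyl and chloro. From the compounds shown here alone, it remains open which part of the ester counts; a carboxylic acid or an amine at the same place would help test this.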